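This account rests on a few compounds, and the source may have more. Where it says the series, first, only, none or still open, it means among the compounds named here.

Measured so far in a functional assay on HCT-116 cells (Homo sapiens) for inhibition, read by sulforhodamine B assay, with a stated time of 72 h; a lower number here means a stronger inhibitor, a higher number a weaker inhibitor:

compound 1 `COc1ccc2cc(C(C)c3nnc4n3N=C(c3ccc(OC(F)(F)F)cc3)CS4)ccc2c1`, 11700 nM
compound 2 `COc1ccc(C2=Nn3c(nnc3C(C)c3ccc4cc(OC)ccc4c3)SC2)cc1`, 6500 nM
compound 3 `CC(C)Cc1ccc(C(C)c2nnc3n2N=C(c2ccc(OC(F)(F)F)cc2)CS3)cc1`, 3000 nM

Compound 1 and compound 2 share one core and differ in a single place, (methyl in place of trifluoromethyl on an oxygen on an aromatic ring). The step that goes with it, a 1.8-fold lower number from compound 1 to compound 2 (0.26 log units; within the scatter), is within the scatter, so the two values are not separated in this assay.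

Compound 3 carries a different core; its difference from compound 1 is not broken down here. In this assay compound 3 gives the lowest of the three numbers, with compound 2 the nearest and compound 1 the furthest, both beyond the scatter, so compound 3 is the strongest inhibitor of the three measured.

Compound 4 `COc1ccc(C2=Nn3c(nnc3C(C)c3ccc(CC(C)C)cc3)SC2)cc1` is not yet measured. It is reached from compound 3 by methyl in place of trifluoromethyl on an oxygen on an aromatic ring. The place is the same as in the earlier pair, so this is the same change applied to the core of compound 3. Placed beside a 1.8-fold lower number from compound 1 to compound 2 (0.26 log units; within the scatter), the step expected from compound 3 to compound 4 is a 1.5-fold lower number from compound 3 to compound 4 (0.18 log units; within the scatter), a similar small movement that is expected to stay within the scatter, because the one earlier instance of this change, a 1.8-fold lower number from compound 1 to compound 2 (0.26 log units; within the scatter), did so.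

Compound 4 is therefore estimated at 2000 nM in this assay, with a range of 800 nM to 6000 nM.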

Compound 4, half-maximal inhibitory concentration: 4200 nM
Estimate against measurement, compound 4: 2.1-fold (0.32 log units) below, within the range that was stated.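

In this assay, trifluoromethoxy to methoxy on the core of compound 3 gives a 1.4-fold higher number from compound 3 to compound 4 (0.15 log units; within the scatter), so the two values are not separated. Set beside the earlier instance on the core of compound 1, the new step does not differ from it: the same change on two cores in this assay, a 1.8-fold lower number (0.26 log units; within the scatter) from compound 1 to compound 2 and a 1.4-fold higher number (0.15 log units; within the scatter) from compound 3 to compound 4, 2.5-fold (0.40 log units) apart, within the scatter of two such steps This shows that, on these two cores, the change carries over without a step that can be told from the scatter, but it does not show that the change is without effect, that the core has no influence on it, or that the same would hold on any further core, since two pairs within the scatter can support none of these.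

As far as these compounds go, whether a longer chain such as ethyl on the same oxygen, or an amine or a carboxylic acid in place of the trifluoromethoxy, would give a step beyond the scatter on either core stays open. Also open, from the compounds shown here alone, is whether the same two pairs would stay unseparated in another cell line, as all the values shown come from this assay.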